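The source may hold more compounds than are shown below. What is called first, only, known or untested is meant among the compounds shown, and "the series" means these compounds.

Compound 1 `CCN(CC)CC(=O)Nc1ccc(-c2nc3cc(C(F)(F)F)ccc3n2C)cc1` is the compound with the highest number among the three measured in an ADME assay on Vero cells (Chlorocebus sabaeus) for cytotoxicity (a higher number here means that more compound is tolerated, a lower number that less compound is tolerated), where compound 1 gives 90000 nM. Compound 2 `Fc1cccc(F)c1-c1nc2cc(C(F)(F)F)ccc2[nH]1` gives 25000 nM and compound 3 `CCN(CC)CC(=O)Nc1ccc(-c2nc3cc(C(F)(F)F)ccc3[nH]2)cc1` gives 24000 nM; both of these are well beyond the scatter below compound 1, so compound 1 is the best tolerated of the three.

Among the compounds with values here, the only measured step within this set is a 3.8-fold lower number from compound 1 to compound 3 (0.57 log units; beyond the scatter). That step touches the core of the molecule, not the side chain, so it says little about the change now in question.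

Compound 4 `Cn1c(-c2ccc(NC(=O)CN3CCCC3)cc2)nc2cc(C(F)(F)F)ccc21` differs from compound 1 in one place: pyrrolidin-1-yl in place of diethylamino on a saturated chain carbon bound to a carbonyl carbon. The amide and its basic nitrogen remain; the two ethyl groups are simply tied together into a ring. Within the data shown here, no measured pair shows this kind of change, so there is no direct guide. In the absence of any such comparison, compound 4 is expected to land close to compound 1, with a step of a 1.1-fold lower number from compound 1 to compound 4 (0.05 log units; within the scatter) in this assay, which is within the scatter. The estimate for compound 4 is therefore 80000 nM, in the range 35000 nM to 180000 nM.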

Compound 4, half-maximal cytotoxic concentration: > 100000 nM
Compound 4 ended at the assay's limit (the forecaster's own chance of this, stated with the estimate: 20%); middle value at least 1.2-fold (0.09 log units) away from the limit.
By their numbers in this assay, from the lowest: compounds 3 and 2 (each within the scatter of the next); then compound 1. At a limit, above all of these: compound 4.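

In this assay compound 4 gives > 100000 nM, which is a limit of the assay and not a number. Within the data shown here, this is the first look at a change in the side chain rather than the core, and tying the two ethyl groups into a ring gives an at least 1.1-fold higher number from compound 1 to compound 4 (0.04 log units; that floor lies within the scatter), so this place tolerates the swap with no fall in the number, though a real rise is not established. How far the step truly reaches cannot be read: the limit of > 100000 nM in this assay, at which 1 of the 4 values shown sits.

Going by these compounds, it remains open how piperidin-1-yl, morpholin-4-yl or dimethylamino would behave on the same saturated chain carbon bound to a carbonyl carbon. Also open, on these data alone, is whether pyrrolidin-1-yl in place of diethylamino would act the same way on compound 3, which has hydrogen in place of methyl on the aromatic nitrogen.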